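A few compounds are considered here, and "the series" means these few. Any claim that something is new, unique, unknown or untested is made for them only; others in the source may bear on it.

In a functional assay on HL-60 cells (Homo sapiens) for inhibition, read by MTT assay, with a stated time of 48 h, tested at 10 uM (a lower number here means less inhibition of growth, a higher number more inhibition of growth at the concentration tested), compound 1 `Cc1cc(=O)c2c(O)cc(OCc3ccco3)c([C@H]3CCN(C)C[C@H]3O)c2o1` gives 32%, compound 2 `Cc1cc(=O)c2c(O)c(CN3CCCC3C(=O)O)c(O)c([C@H]3CCN(C)C[C@H]3O)c2o1` gives 16%, and compound 3 `Cc1oc2c([C@H]3CCN(C)C[C@H]3O)c(O)cc(O)c2c(=O)c1C(O)c1ccc([N+](=O)[O-])cc1` gives 0%. Compound 3 therefore stands lowest of the three numbers: its nearest neighbour is compound 2 and its furthest is compound 1, and both gaps lie beyond the scatter. Compound 4 `CCOc1ccc(Br)c(C(O)c2c(C)oc3c([C@H]4CCN(C)C[C@H]4O)c(O)cc(O)c3c2=O)c1` keeps the core of compound 3 and differs from it in one place only: 2-bromo-5-ethoxyphenyl in place of 4-nitrophenyl on a saturated chain carbon bound to an aromatic carbon and an oxygen on a saturated carbon. Going by the values given here, no measured pair shows what such a change does, so the expectation rests on compound 3 alone, which gives 0%. The step of a number 8 percentage points higher from compound 3 to compound 4 (within the scatter) is expected to be small and to stay within the scatter, with no clear direction. Compound 4 is estimated at 8%, within a range from 0% to 28%.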

Compound 4, percent growth inhibition at one concentration: 2%
Compound 4: the middle estimate sits 6 percentage points above what was measured; the range from low to high includes it.
By their numbers in this assay, from the lowest: compounds 3 and 4 (each within the scatter of the next); then compound 2; then compound 1.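

In this assay, the first pair differing in one place gives a number 2 percentage points higher from compound 3 to compound 4 (within the scatter), with 2-bromo-5-ethoxyphenyl in place of 4-nitrophenyl on a saturated chain carbon bound to an aromatic carbon and an oxygen on a saturated carbon. At this position, then, the two substituted phenyl groups cannot be told apart, although they share no substituent. Nothing available explains this result. As far as these compounds go, whether a pyridine ring or an unsubstituted phenyl at this carbon would read differently remains open, as does whether any aryl group here can raise the number beyond the scatter.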